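The source may hold more compounds than are shown below. What is called first, only, known or untested is meant among the compounds shown, and "the series" means these compounds.

Working notes on the series. In a functional assay on T29Kt1 cells (Homo sapiens) for cytotoxicity, read by sulforhodamine B assay, with a stated time of 3 days (a higher number here means a weaker inhibitor, a lower number a stronger inhibitor), compound 1 (`OCc1cn(Cc2cccc(Br)c2)c2ccccc12`) gives 32 nM and compound 2 (`OCc1cn(Cc2cccc(I)c2)c2ccccc12`) gives 20 nM. These two values lie within the scatter of each other, so compound 2 stands level with compound 1 on the numbers available.

Compound 3 (`O=[N+]([O-])c1cccc(Cn2cc(CO)c3ccccc32)c1`) departs from compound 2 in one place: nitro in place of iodo on an aromatic carbon. This is nitro in place of iodo on an aromatic carbon, meta to a large group.

For the measured compounds named here, only one measured step bears on this change, a 1.6-fold lower number from compound 1 to compound 2 (0.20 log units; within the scatter). Going by the values given here, that step exchanges bromo for iodo, and no measured compound carries anything else at this place, so the data give only weak guidance for nitro.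

A modest rise in this assay is expected, with a wide margin, and the expected step is a 2.5-fold higher number from compound 2 to compound 3 (0.40 log units; beyond the scatter). For compound 3 the estimated value is 50 nM, with an expected range from 15 nM to 200 nM.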

Compound 3, half-maximal inhibitory concentration: 390 nM
The estimate for compound 3 lay 7.8-fold (0.89 log units) below the measured number; measured number above the stated range.
By their numbers in this assay, from the lowest: compounds 2 and 1 (each within the scatter of the next); then compound 3.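

Nitro brings a 20-fold higher number from compound 2 to compound 3 (1.29 log units; beyond the scatter) and a 12-fold higher number from compound 1 to compound 3 (1.09 log units; beyond the scatter) in this assay while bromo and iodo stand within the scatter of each other, so this place on the aromatic ring is not indifferent to the group it carries. The level shared by compound 1 and compound 2 therefore holds for these two halogens but does not extend to nitro, and compound 3 is the weakest of the three inhibitors. No measurement available here bears on what lies behind this large step.

As far as these compounds go, whether an amine, a methoxy group or a carboxylic acid at this place would stay level with the halogens or rise towards compound 3 remains open. Also open, from the compounds shown here alone, is whether the same exchange of halogen for nitro would give a step of similar size elsewhere on this ring.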